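Ortho substituent swap on the aryl amide of compound 2

The source may hold more compounds than are shown below. What is called first, only, known or untested is meant among the compounds shown, and "the series" means these compounds.

Measured so far in an assay on cells for displacement of a labelled ligand from Orexin receptor type 2 (Homo sapiens); a lower number here means a stronger inhibitor, a higher number a weaker inhibitor:
compound 1 `COC(=O)c1cccnc1N[C@@H]1CC[C@@H](C)N(C(=O)c2ccccc2-n2nccn2)C1` gives 0.4 nM
compound 2 `Cc1c(C#N)ccnc1O[C@@H]1CC[C@@H](C)N(C(=O)c2ccccc2C(F)(F)F)C1` gives 3.1 nM
compound 3 `CC(=O)Nc1cc(C(=O)N2C[C@H](Oc3nccc(C#N)c3C)CC[C@H]2C)c(-c2ccccc2)cn1` gives 0.7 nM

Compound 2 stands at the highest number of the three; compound 3 sits at a lower number, beyond the scatter, and compound 1 at a lower number still, also beyond the scatter. Going by the values given here, compounds 1 and 3 carry different amide-side aromatics and a different linking atom from compound 2, so no single-point step between measured compounds is available.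

Compound 4 `CCOc1ccccc1C(=O)N1C[C@H](Oc2nccc(C#N)c2C)CC[C@H]1C` keeps the whole of compound 2 except for one group on the amide-side ring: ethoxy in place of trifluoromethyl on an aromatic carbon. Among the compounds with values here, no measured pair isolates this change, so the expected step from compound 2 to compound 4 in this assay is taken as none beyond the scatter, with the direction open; the estimate a 1.0-fold lower number from compound 2 to compound 4 (0.01 log units; within the scatter) reflects that.

Compound 4 is expected to give 3 nM in this assay, within the range 0.8 nM to 12 nM.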

Compound 4, inhibition constant: 0.7 nM
For compound 4 the middle estimate is 4.3-fold (0.63 log units) above the measured one; measured number outside the range, below it.
By their numbers in this assay, from the lowest: compounds 1, 3 and 4 (each within the scatter of the next); then compound 2.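

In this assay, going by these compounds alone, ethoxy in place of trifluoromethyl on an aromatic carbon, ortho to a large group, gives the only single-point step (a 4.4-fold lower number from compound 2 to compound 4 (0.65 log units; beyond the scatter)). This shows that, with the rest of compound 2 held fixed, the group at this position on the amide-side ring changes the number beyond the scatter. The change also swaps a group with no hydrogen-bond acceptor for one with a single acceptor, but no available data explain the step, and this one pair cannot tie it to that count or to any other difference between the groups.

As far as these compounds go, whether a methoxy group, a longer alkoxy chain or an amine at this position would give a similar number remains open. Also open, from the compounds shown here alone, is whether the same swap would give a step of similar size on the core of compound 1, which has a different linking atom.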